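The compounds below may be only part of what the source reports. "The series", "measured", "known", "first", "only" and "open" are said of these compounds alone.

Working notes on the series. In a functional assay on the whole organism (strain Wistar) for inhibition, with Rattus norvegicus as the target, read by paw edema, with a stated time of 30 min, at a dose of 10 mg/kg by the intraperitoneal route (on this read-out higher numbers stand for more inhibition at the one dose given (going by the name of the read-out) and lower numbers for less inhibition), compound 1 `O=C(N/N=C/c1cccc(F)c1)c1cccnc1Nc1cccc(C(F)(F)F)c1` gives 58.3%, compound 2 `O=C(N/N=C/c1cccc(O)c1)c1cccnc1Nc1cccc(C(F)(F)F)c1` gives 67.5%, and compound 3 `COc1ccc(/C=N/NC(=O)c2cccnc2Nc2cccc(C(F)(F)F)c2)cc1` gives 50.4%. The steps of a number 9.2 percentage points higher from compound 1 to compound 2 (within the scatter) and a number 7.9 percentage points lower from compound 1 to compound 3 (within the scatter) both stay within the scatter, whereas a number 17.1 percentage points lower from compound 2 to compound 3 (beyond the scatter) goes beyond it. Compound 3 thus stands below compound 2 by a gap beyond the scatter, while its gap to compound 1 is within the scatter.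

Compound 4 `COc1ccc(/C=N/NC(=O)c2cccnc2Nc2cccc(C(F)(F)F)c2)c(OC)c1` differs from compound 3 by methoxy in place of hydrogen on an aromatic carbon, the aryl going from 4-methoxyphenyl to 2,4-dimethoxyphenyl. For the measured compounds named here, no measured step adds a group to a ring that already carries one; the nearest precedents are exchanges of one ring substituent for another, a number 7.9 percentage points lower from compound 1 to compound 3 (within the scatter) within the scatter and a number 17.1 percentage points lower from compound 2 to compound 3 (beyond the scatter) beyond it, and they give no ground for a shift in either direction beyond the scatter. Compound 4 is therefore expected to give about 50%, with a range from 38% to 62%. For compound 4 the expected step is a number 0.4 percentage points lower from compound 3 to compound 4 (within the scatter), that is, none beyond the scatter.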

Compound 4, a percentage reported as inhibition, in the whole organism at one dose (the size of the read-out at that dose, not a potency): 37.8%
Beside the measured number, compound 4's estimate is 12.2 percentage points above it; the whole stated range lies above it.
By their numbers in this assay, from the lowest: compound 4; then compounds 3, 1 and 2 (each within the scatter of the next, the first and the last beyond it).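

In this assay, for the compounds shown here, the step of a number 12.6 percentage points lower from compound 3 to compound 4 (beyond the scatter) is the first measured one that adds a group to a ring already carrying one rather than exchanging one substituent for another, and it shows that a methoxy on this aromatic carbon, ortho to a large group and meta to a methoxy group, lowers the number beyond the scatter. The 2,4-dimethoxyphenyl compound also falls beyond the scatter against both other aryl groups, with a number 29.7 percentage points lower from compound 2 to compound 4 (beyond the scatter) and a number 20.5 percentage points lower from compound 1 to compound 4 (beyond the scatter) as the further steps, so compound 4 holds the lowest number of the four. No measurement at hand bears on why the added methoxy has this effect.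

From the compounds shown here alone, it stays open whether the fall follows the methoxy itself or any group at this place. An amine or a chloro on the same aromatic carbon would separate the two readings.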